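Removing the chloro from compound 1: cytotoxicity notes

The source may report more compounds than this note shows. Statements on the series, on what has been measured and on what is new or still open speak of the compounds shown alone.

- compound 1 `CCN(CC)CN1C(=O)/C(=N/NC(N)=S)c2cc(Cl)ccc21` gives 78300 nM as measured
- compound 2 `CCN(CC)CN1C(=O)/C(=N/NC(=S)Nc2ccc(C)cc2)c2cc(Cl)ccc21` gives 11300 nM as measured
- compound 3 `CCN(CC)CN1C(=O)/C(=N/NC(N)=S)c2ccccc21` has not yet been measured

In an ADME assay on MDCK cells (Canis lupus familiaris) for cytotoxicity (on this read-out lower numbers stand for higher toxicity in this test and higher numbers for lower toxicity in this test), compound 1 gives 78300 nM as the higher of the two measured numbers. Compound 3 differs from it in one place (hydrogen in place of chloro on an aromatic carbon) with hydrogen in place of chloro on an aromatic carbon. Among the measured compounds shown here, the only measured step is a 6.9-fold lower number from compound 1 to compound 2 (0.84 log units; beyond the scatter) for 4-methylphenyl in place of hydrogen on an amide-type nitrogen. For the measured compounds named here, that modest step lies elsewhere on the molecule, and no measured pair tests the chloro itself, so it gives only a loose sense of scale. No step beyond the scatter is therefore expected in this assay and no direction can be favoured. The estimated step is a 1.1-fold higher number from compound 1 to compound 3 (0.04 log units; within the scatter) for now. Compound 3 is expected near 85000 nM with an estimated range of 35000 nM to 200000 nM in this test.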

Compound 3, half-maximal cytotoxic concentration: 85800 nM
Estimate against measurement, compound 3: 1.0-fold (0.00 log units) below; the measured number falls inside the stated range.
By their numbers in this assay, from the lowest: compound 2; then compounds 1 and 3 (each within the scatter of the next).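

In this assay, among the compounds shown here, the chloro is tested directly for the first time, and hydrogen in place of chloro on an aromatic carbon gives a 1.1-fold higher number from compound 1 to compound 3 (0.04 log units; within the scatter). The chloro can therefore be lost from the core of compound 1 without a step beyond the scatter, while 4-methylphenyl in place of hydrogen on an amide-type nitrogen gives a 6.9-fold lower number from compound 1 to compound 2 (0.84 log units; beyond the scatter), the only step beyond the scatter among these compounds. No measurement is available to explain why the chloro change leaves the number within the scatter.

Open, going by these compounds, is whether a methoxy group or an amine on that aromatic carbon would also stay within the scatter of compound 1 in this assay. Also open, on these data alone, is whether removing the chloro would read the same with the 4-methylphenyl of compound 2 in place.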